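From 2-phenylethynyl to 2-phenylethenyl on a shared core

The source may hold more compounds than are shown below. What is called first, only, known or untested is meant among the compounds shown, and "the series" means these compounds.

Compound 1 (`CCCC#Cc1cc([C@@H]2O[C@H](CO)[C@@H](O)[C@H]2O)n2ncnc(N)c12`) gives 20 nM in a functional assay on Z-138 cells (Homo sapiens) for antiproliferative activity, with a stated time of 72 h (a lower number here means a stronger inhibitor, a higher number a weaker inhibitor), and compound 3 (`Nc1ncnn2c([C@@H]3O[C@H](CO)[C@@H](O)[C@H]3O)cc(-c3ccoc3)c12`) gives 300 nM there. Compound 2 (`Nc1ncnn2c([C@@H]3O[C@H](CO)[C@@H](O)[C@H]3O)cc(C#Cc3ccccc3)c12`) gives 41400 nM as the highest number of the three, which makes it the weakest inhibitor among them. Compound 4 (`Nc1ncnn2c([C@@H]3O[C@H](CO)[C@@H](O)[C@H]3O)cc(/C=C/c3ccccc3)c12`) differs from compound 2 in one group (2-phenylethenyl in place of 2-phenylethynyl on an aromatic carbon): 2-phenylethenyl in place of 2-phenylethynyl on an aromatic carbon.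

Among the measured compounds shown here, no measured step turns a triple bond into a double bond, so the evidence is indirect. Three large steps bear on the change. Phenyl in place of propyl on a triple-bonded carbon cost a great deal (a 2100-fold higher number from compound 1 to compound 2 (3.32 log units; beyond the scatter)), while furan-3-yl in place of pent-1-yn-1-yl cost much less (a 15-fold higher number from compound 1 to compound 3 (1.18 log units; beyond the scatter)). Removing 2-phenylethynyl altogether brought a steep recovery (a 140-fold lower number from compound 2 to compound 3 (2.14 log units; beyond the scatter)). Compound 4 keeps the phenyl ring, so only a partial recovery seems likely, and the data cannot separate the part played by the triple bond from that played by the phenyl. A large step towards a lower number is therefore expected in this assay (a 6.9-fold lower number from compound 2 to compound 4 (0.84 log units; beyond the scatter)), though with wide uncertainty. The estimate for compound 4 is 6000 nM (expected range 600 nM to 40000 nM).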

Compound 4, half-maximal inhibitory concentration: 1300 nM
Beside the measured number, compound 4's estimate is 4.6-fold (0.66 log units) above it; measured number inside the range.
By their numbers in this assay, from the lowest: compound 1; then compound 3; then compound 4; then compound 2.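

With the phenyl ring and the count of heavy atoms unchanged, going from a triple to a double bond outside the ring gave a 32-fold lower number from compound 2 to compound 4 (1.50 log units; beyond the scatter) in this assay. The earlier compounds shown here changed the phenyl ring and the triple bond together or left the bond in place, whereas this step shows that the bond alone, on this aromatic carbon of the five-membered ring, can move the number by a large amount. Even so, 2-phenylethenyl does not match the smaller groups: the step to it from the pent-1-yn-1-yl compound is large, a 65-fold higher number from compound 1 to compound 4 (1.81 log units; beyond the scatter), while the step from the furan-3-yl compound is only modest, a 4.3-fold higher number from compound 3 to compound 4 (0.64 log units; beyond the scatter), though still beyond the scatter, and nothing available explains these differences.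

The compounds shown leave open whether a 2-phenylethyl group, with no multiple bond outside the ring, would continue the trend from triple to double bond. They also leave open how much of the remaining gap to compound 1 belongs to the phenyl ring itself, which a pent-1-en-1-yl chain or a cyclohexyl ring in its place would help to settle.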